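A few compounds are considered here, and "the series" means these few. Any claim that something is new, unique, unknown or untested is made for them only; others in the source may bear on it.

Measured in a functional assay on THP-1 cells (Homo sapiens) for cytotoxicity, read by MTT assay, with a stated time of 24 h; a lower number here means a stronger inhibitor, a higher number a weaker inhibitor:

compound 1, `CCCCCCCCCCn1cc(-c2nc3ccccc3cc2CCCC)nn1`: > 100 ug/mL
compound 2, `Cc1cc2ccccc2nc1-c1cn(-c2ccc(F)cc2)nn1`: > 100 ug/mL
compound 3, `CCCCCc1cc2ccccc2nc1-c1cn(CCC(F)(F)C(F)(F)C(F)(F)C(F)(F)C(F)(F)C(F)(F)C(F)(F)C(F)(F)F)nn1`: > 100 ug/mL

Each of these three values is a limit of the assay, not a number. Within the data shown here, compound 2 therefore stands exactly where the other two stand, at the limit of > 100 ug/mL in this assay, at which 3 of the 3 values shown sit, and no compound shows a number inside the measurable range. Compound 4, `CCc1cc2ccccc2nc1-c1cn(-c2ccc(F)cc2)nn1`, differs from compound 2 by methyl in place of hydrogen on a saturated chain carbon bound to an aromatic carbon. Among the measured compounds shown here, no measured pair shows what such a change does, and with every value at the limit there is no step to build on. Compound 4 is expected to remain at the limit too, so the step of a number no higher from compound 2 to compound 4 (the limit leaves the size open) is expected to be none beyond the scatter. For compound 4 the estimate is 100 ug/mL, with a range from 50 ug/mL to 300 ug/mL.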

Compound 4, half-maximal inhibitory concentration: > 100 ug/mL
Compound 4: only a limit was reported (the forecaster's own chance of this, stated with the estimate: 85%); the middle value sits exactly at the limit.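

Compound 2 and compound 4 each carry only a limit, not a number, so no step can be read between them: the limit of > 100 ug/mL in this assay, at which 4 of the 4 values shown sit.

The compounds shown leave open whether any change to these structures would give a value inside the measurable range.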